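Fluoro to Methoxy: What Compound 3 May Show

The compounds below may be only part of what the source reports. "The series", "measured", "known", "first", "only" and "open" are said of these compounds alone.

Compound 1 `Oc1cc(C(F)(F)F)ccc1-c1nc(-c2ccccc2O)n(-c2ccccc2Cl)n1` and compound 2 `Oc1cc(C(F)(F)F)ccc1-c1nc(-c2ccccc2O)n(-c2cccc(F)c2)n1` share one core and differ only in the ring carried on the aromatic nitrogen. In a functional assay on PC-12 cells (Rattus norvegicus) for cytotoxicity, read by MTT assay, with stated times of 2 h and 24 h, tested at 1 uM (on this read-out higher numbers stand for a stronger effect at the one concentration tested and lower numbers for a weaker effect), compound 1 gives 70.1% and compound 2 gives 67.2%; on paper compound 2 holds the smaller of the two numbers, but the step of a number 2.9 percentage points lower from compound 1 to compound 2 (within the scatter) is within the scatter, so the two cannot be told apart.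

Compound 3 `COc1cccc(-n2nc(-c3ccc(C(F)(F)F)cc3O)nc2-c2ccccc2O)c1` keeps everything of compound 2 except one change: methoxy in place of fluoro on an aromatic carbon. Within the data shown here, no measured step involves a methoxy group; the only step available changed the ring on the aromatic nitrogen and stayed within the scatter. Nothing therefore points to a shift beyond the scatter in this assay for compound 3. The step expected, a number 1.2 percentage points lower from compound 2 to compound 3 (within the scatter), is close to none. Compound 3 is estimated at 66%, within 52% to 80%.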

Compound 3, a percentage reported as activity, at one concentration (the size of the read-out at that concentration, not a potency): 68.3%
For compound 3 the middle estimate is 2.3 percentage points below the measured one; low and high end bracket the measured number.
By their numbers in this assay, from the lowest: compounds 2, 3 and 1 (each within the scatter of the next).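

At this place on the ring carried by the aromatic nitrogen, meta to a large group, methoxy brings a hydrogen-bond acceptor that fluoro does not, yet this assay gives a number 1.1 percentage points higher from compound 2 to compound 3 (within the scatter) as the result of the change. Measured against the 2-chlorophenyl ring, the 3-methoxyphenyl ring gives a number 1.8 percentage points lower from compound 1 to compound 3 (within the scatter) as its step, so compound 1, compound 2 and compound 3 cannot be told apart, and a change of substituent on this ring has not yet moved the number beyond the scatter. Nothing measured here explains why the number stays so close.

The three compounds leave open whether an amine or a carboxylic acid at this place would give a step beyond the scatter. They also leave open whether a longer chain such as butoxy would do so where methoxy does not.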